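The source may report more compounds than this note shows. Statements on the series, on what has been measured and on what is new or still open speak of the compounds shown alone.

Compound 1 `CCn1nc(-n2ccnc2)c2ccccc2c1=O` gives 53% in an assay on isolated protein (Oryctolagus cuniculus) with Thromboxane-A synthase (Homo sapiens) as the target, tested at 1 uM; on this read-out higher numbers stand for more inhibition at the one concentration tested (going by the name of the read-out) and lower numbers for less inhibition. Compound 2 `CCn1nc(-n2cncn2)c2ccccc2c1=O` gives 0%. Compound 3 `CCn1nc(-c2cnccn2)c2ccccc2c1=O` gives 37%.

Compound 3 holds the second highest of the three numbers: a number 16 percentage points lower from compound 1 to compound 3 (beyond the scatter), while a number 37 percentage points higher from compound 2 to compound 3 (beyond the scatter). Compound 4 `CCn1nc(-c2cncnc2)c2ccccc2c1=O` differs from compound 3 in one place: pyrimidin-5-yl in place of pyrazin-2-yl on an aromatic carbon. For the measured compounds named here, no measured step trades one six-membered ring for another, so the two steps touching compound 3 are the only guide; both are beyond the scatter, one modest and one large, showing that the ring on this carbon matters, but neither fixes a direction for pyrimidin-5-yl. Compound 4 is therefore expected near compound 3, with a number 2 percentage points lower from compound 3 to compound 4 (within the scatter). The estimate for compound 4 is 35%, between 5% and 65%.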

Compound 4, a percentage reported as inhibition, at one concentration (the size of the read-out at that concentration, not a potency): 26%
Compound 4: the middle estimate sits 9 percentage points above what was measured; measured number inside the range.
By their numbers in this assay, from the lowest: compound 2; then compound 4; then compound 3; then compound 1.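

Pyrimidin-5-yl in place of pyrazin-2-yl gives a number 11 percentage points lower from compound 3 to compound 4 (beyond the scatter) with the atom counts unchanged, so where the two ring nitrogens stand matters on this carbon, not only how many there are. Pyrimidin-5-yl also gives a number 26 percentage points higher from compound 2 to compound 4 (beyond the scatter) but a number 27 percentage points lower from compound 1 to compound 4 (beyond the scatter) and so, like pyrazin-2-yl, falls between the 1H-1,2,4-triazol-1-yl and 1H-imidazol-1-yl compounds. Nothing measured here accounts for these differences.

As far as these compounds go, whether pyridin-3-yl, with a single ring nitrogen, or an amine on this carbon would come closer to 1H-imidazol-1-yl stays open. So does the outcome of a longer chain in place of the ethyl group.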